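The source may hold more compounds than are shown below. What is called first, only, known or untested is meant among the compounds shown, and "the series" means these compounds.

Compound 1 `CC/C(=C(/c1ccc(/C=C/C(=O)O)cc1)c1cc2ccccc2[nH]1)c1ccccc1` gives 108 nM in a functional assay on MCF7 cells (Homo sapiens) for inhibition; on this read-out higher numbers stand for weaker inhibition and lower numbers for stronger inhibition.
Compound 2 `CC/C(=C(/c1ccc(/C=C/C(=O)O)cc1)c1cc2ccccc2[nH]1)c1cccc(OC(F)(F)F)c1` gives 282 nM in this assay.
Compound 3 `CC/C(=C(/c1ccc(/C=C/C(=O)O)cc1)c1cc2ccccc2[nH]1)c1ccc(OC)cc1` gives 61 nM in this assay.

Compound 3 carries the lowest number of the three. Its nearest neighbour is compound 1, and the step of a 1.8-fold lower number from compound 1 to compound 3 (0.25 log units; within the scatter) lies within the scatter, so the two cannot be told apart; against compound 2 the step of a 4.6-fold lower number from compound 2 to compound 3 (0.66 log units; beyond the scatter) lies beyond the scatter.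

Compound 4 `CC/C(=C(/c1ccc(/C=C/C(=O)O)cc1)c1cc2ccccc2[nH]1)c1ccc(C#N)cc1Cl` differs from compound 3 in one place: 2-chloro-4-cyanophenyl in place of 4-methoxyphenyl on a double-bonded chain carbon bound to a double-bonded chain carbon and a saturated chain carbon. Within the data shown here, two measured steps bear on this. The step of a 2.6-fold higher number from compound 1 to compound 2 (0.42 log units; beyond the scatter) shows that adding a trifluoromethoxy group to the phenyl ring weakened inhibition beyond the scatter, while a 1.8-fold lower number from compound 1 to compound 3 (0.25 log units; within the scatter) shows that a methoxy group changed little. Compound 4 removes the methoxy group and brings in two new groups, a chloro and a cyano, on that same ring. Since the one substituent of this broader kind that was tried weakened inhibition, a modest rise in the number is expected for compound 4, a step of a 3.3-fold higher number from compound 3 to compound 4 (0.52 log units; beyond the scatter) in this assay, with the direction more certain than the size. Compound 4 is therefore estimated at 200 nM in this assay, with a likely range from 60 nM to 650 nM.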

Compound 4, half-maximal inhibitory concentration: 49 nM
The estimate for compound 4 lay 4.1-fold (0.61 log units) above the measured number, outside the stated range (below it).
By their numbers in this assay, from the lowest: compounds 4, 3 and 1 (each within the scatter of the next, the first and the last beyond it); then compound 2.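

Among these compounds, compound 4 is the first in this set whose ring on the double-bonded chain carbon carries two groups, and in this assay the exchange of 4-methoxyphenyl for 2-chloro-4-cyanophenyl leaves no readable difference: a 1.2-fold lower number from compound 3 to compound 4 (0.10 log units; within the scatter). Against the other two rings the same group does separate, with a 2.2-fold lower number from compound 1 to compound 4 (0.34 log units; beyond the scatter) and a 5.8-fold lower number from compound 2 to compound 4 (0.76 log units; beyond the scatter), so a larger substituted ring at this place is compatible with inhibition at least as strong as that of the plain phenyl, and among the substituted rings only the 3-(trifluoromethoxy)phenyl of compound 2 goes against this by giving weaker inhibition than phenyl. No measurement here explains why these rings differ.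

The chloro and the cyano group appear only together, in compound 4, so the compounds shown leave open how much of the step from the plain phenyl belongs to each of them. Going by these compounds, it also remains open how this place would respond to a different kind of group on the ring, such as an amine or a hydroxyl group, or to a ring bearing three substituents.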